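This account rests on a few compounds, and the source may have more. Where it says the series, first, only, none or still open, it means among the compounds named here.

Measured compounds:
compound 1, `OC(c1ccc(Br)cc1)(c1ccc(C(F)(F)F)cc1)c1cccnc1`: 54700 nM
compound 2, `NC(=O)c1cccc(C(O)(c2ccc(C(F)(F)F)cc2)c2cccnc2)c1`: > 100000 nM

Among the compounds with values here, in an ADME assay on L6 cells (Rattus norvegicus) for cytotoxicity, read by resazurin assay, with a stated time of 72 h (a lower number here means a stronger inhibitor, a higher number a weaker inhibitor), compound 1 gives 54700 nM, which is the only number among the values shown. Compound 2 reaches only the limit of > 100000 nM in this assay, a limit rather than a number. This is the limit of > 100000 nM in this assay, at which 1 of the 2 values shown sits. Within the data shown here, the single measured step is an at least 1.8-fold higher number from compound 1 to compound 2 (0.26 log units; that floor lies within the scatter), and its floor lies within the scatter of this assay.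

Compound 3, `OC(c1ccc(C(F)(F)F)cc1)(c1ccc(C(F)(F)F)cc1)c1cccnc1`, is the compound not yet measured. It differs from compound 1 in one place: trifluoromethyl in place of bromo on an aromatic carbon. The measured step from compound 1 to compound 2 changes a different group at a different place, and it already tells of no change beyond the scatter, so it gives little direction for the present change. Compound 3 is therefore expected to sit close to compound 1, with the estimated step of a 1.1-fold lower number from compound 1 to compound 3 (0.04 log units; within the scatter) lying within the scatter. Compound 3 is expected to give about 50000 nM in this assay, with an estimated range from 20000 nM to 120000 nM.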

Compound 3, half-maximal inhibitory concentration: 50600 nM
The estimate for compound 3 lay 1.0-fold (0.01 log units) below the measured number, within the range that was stated.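

In this assay, the exchange of bromo for trifluoromethyl on this aromatic carbon, para to a large group, gives a 1.1-fold lower number from compound 1 to compound 3 (0.03 log units; within the scatter) and so leaves compound 1 and compound 3 within the scatter of each other. Within the data shown here, this is the first change whose size can be read from two numbers, since the earlier step, at a different place, rested on a limit; it shows that at this position a single bromine and a trifluoromethyl group of carbon and fluorine give values that cannot be told apart in this cell read-out. Nothing shown here gives a cause for this outcome.

On these data alone, the pair covers only these two groups, so it remains open whether an amine, a carboxylic acid, a nitrile or a longer chain on this aromatic carbon would also stay within the scatter of compound 1. It also remains open whether the same exchange would behave alike on a core carrying another group in place of the second trifluoromethyl-bearing ring, or in any read-out other than this assay as shown here.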